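Notes on the step from compound 2 to compound 3

This account rests on a few compounds, and the source may have more. Where it says the series, first, only, none or still open, it means among the compounds named here.

Values so far in a functional assay on SW-620 cells (Homo sapiens) for antiproliferative activity, read by MTT assay, with a stated time of 72 h; on this read-out lower numbers stand for stronger inhibition and higher numbers for weaker inhibition:
- compound 1 `O=C1O/C(=C\Cn2cnc3ccn(C/C=C4\OC(=O)C(OCc5ccccc5)=C4OCc4ccccc4)c3c2=O)C(OCc2ccccc2)=C1OCc1ccccc1` gives 47200 nM
- compound 2 `O=C1NC(O)(CCn2cnc3cc[nH]c3c2=O)C(OCc2ccccc2)=C1OCc1ccccc1` gives 90700 nM

These two numbers lie within the scatter of each other, so compound 2 stands level with compound 1 in this assay and neither can be ranked. Compound 3 `O=C1NC(O)(CCn2cnc3ccnc(Cl)c32)C(OCc2ccccc2)=C1OCc1ccccc1` departs from compound 2 on one point, (a group of 10 heavy atoms (6 carbon, 3 nitrogen, 1 chlorine; one five-membered aromatic ring with 2 hetero atoms, one six-membered aromatic ring with 1 hetero atom) in place of a group of 10 heavy atoms (6 carbon, 3 nitrogen, 1 oxygen; one five-membered aromatic ring with 1 hetero atom, one six-membered aromatic ring with 2 hetero atoms), on a saturated chain carbon, two bonds along the chain from a saturated ring carbon). The group that enters carries chlorine.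

Among the measured compounds shown here, no measured step covers this exchange. For the measured compounds named here, the only anchors are compound 1 at 47200 nM and compound 2 at 90700 nM, so the expectation is loose. A modest move toward stronger inhibition is expected, and the estimated change is a 2.6-fold lower number from compound 2 to compound 3 (0.41 log units; beyond the scatter). For compound 3 the expected value is 35000 nM, with an estimated range of 9000 nM to 110000 nM.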

Compound 3, half-maximal inhibitory concentration: > 100000 nM
Compound 3: a limit, no number; the forecaster's own chance of this, stated with the estimate: 25%; middle value at least 2.8-fold (0.45 log units) from the limit.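

In this assay compound 3 gives a limit, not a number: the limit of > 100000 nM in this assay, at which 1 of the 3 values shown sits.

The exchange on a saturated chain carbon, two bonds along the chain from a saturated ring carbon, reads as an at least 1.1-fold higher number from compound 2 to compound 3 (0.04 log units; that floor lies within the scatter), so the group carrying chlorine shows no gain in inhibition, while the true size of the change remains unread. The exchange alters several features at once: the oxygen and the hydrogen-bond donor leave, chlorine enters, and the hetero atoms are distributed differently over the two rings, so the result cannot be assigned to any one of these.

On these data alone, it remains open whether chlorine itself matters, which an amine or a methoxy group in its place on the same core would test. A longer chain to the ring carbon would show whether the chain length bears on the read-out.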